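The source may hold more compounds than are shown below. What is called first, only, known or untested is meant among the compounds shown, and "the series" means these compounds.

Two pairs of compounds are compared here in an assay for inhibition of Amine oxidase [flavin-containing] B (Bos taurus), read by fluorescence, with a stated time of 60 min; a lower number here means a stronger inhibitor, a higher number a weaker inhibitor. Compound 1, `COc1ccc(C(=O)NNc2nc3ccccc3nc2Cc2ccccc2)cc1`, carries a methoxy group on its outer benzene ring and gives 920000 nM. Compound 2, `O=C(NNc1nc2ccccc2nc1Cc1ccccc1)c1ccc(Br)cc1`, differs from it in one place only, (bromo in place of methoxy on an aromatic carbon), and gives 980000 nM. The step between them is a 1.1-fold higher number from compound 1 to compound 2 (0.03 log units; within the scatter), so these two values cannot be told apart.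

Compound 3, `COc1ccc(/C=N/NC(=O)Cn2c(=O)c(Cc3ccccc3)nc3ccccc32)cc1`, is built on a different core; the difference between its core and the core of compound 1 is not broken down here. In this assay compound 3 gives 82000 nM, the lowest of the three numbers, and its gaps to compound 1 and compound 2 both lie beyond the scatter.

Compound 4, `O=C(Cn1c(=O)c(Cc2ccccc2)nc2ccccc21)N/N=C/c1ccc(Br)cc1`, has not yet been measured. Going by the values given here, it differs from compound 3 by bromo in place of methoxy on an aromatic carbon, the same change, at the same place, as the one that turns compound 1 into compound 2. Because that change gave a 1.1-fold higher number from compound 1 to compound 2 (0.03 log units; within the scatter), the step from compound 3 to compound 4 is expected to be about as small, a 1.1-fold higher number from compound 3 to compound 4 (0.04 log units; within the scatter). Nothing among these compounds suggests that swapping the core should alter how this one change plays out. Compound 4 is therefore expected to give 90000 nM, most likely somewhere between 45000 nM and 180000 nM.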

Compound 4, half-maximal inhibitory concentration: 26000 nM
For compound 4 the middle estimate is 3.5-fold (0.54 log units) above the measured one; measured number below the stated range.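

On the core of compound 3, bromo in place of methoxy gives a real step, a 3.2-fold lower number from compound 3 to compound 4 (0.50 log units; beyond the scatter), whereas the same change on the core of compound 1 gives two values that cannot be told apart. Set side by side, the two steps do not agree, so in this series the step seen on one core was a poor guide to the step on the other: the same change on two cores in this assay, a 1.1-fold higher number (0.03 log units; within the scatter) from compound 1 to compound 2 and a 3.2-fold lower number (0.50 log units; beyond the scatter) from compound 3 to compound 4, 3.4-fold (0.53 log units) apart, beyond the scatter of two such steps This shows that the change does not carry over unaltered between these two cores, but it does not show why, and it rests on a single pair of compounds on each core, so it is no general rule for either core.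

The compounds shown compare only methoxy and bromo at this place on the ring, so it remains open whether another group there, such as chloro, an amine or a carboxylic acid, would also behave differently on the two cores. From the compounds shown here alone, it also remains open which part of the difference between the two cores goes with the different steps, and whether the gain seen with compound 4 would hold on other close relatives of compound 3.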